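Piperidine amine variation on the shared indole core

The source may report more compounds than this note shows. Statements on the series, on what has been measured and on what is new or still open speak of the compounds shown alone.

Measured compounds:
compound 1 `CN(CC1CCN(CCCc2c[nH]c3ccc(-n4cnnc4)cc23)CC1)C(=O)Nc1ccccc1`, 6.2 nM
compound 2 `OC[C@H](NC1CCN(CCCc2c[nH]c3ccc(-n4ccnc4)cc23)CC1)c1ccccc1`, 100 nM
compound 3 `O[C@@H]1Cc2ccccc2[C@H]1NC1CCN(CCCc2c[nH]c3ccc(-n4cnnc4)cc23)CC1`, 210 nM

In an assay on CHO cells for displacement of a labelled ligand from 5-hydroxytryptamine receptor 1B (Homo sapiens) (on this read-out lower numbers stand for stronger inhibition and higher numbers for weaker inhibition), compound 1 gives the lowest number of the three, with compound 2 and compound 3 both beyond the scatter above it. Compound 4 `CC(=O)Nc1ccc(CNCC2CCN(CCCc3c[nH]c4ccc(-n5cnnc5)cc34)CC2)cc1` is not yet measured in this assay. It differs from compound 1 by (4-acetamidobenzyl)amino in place of methyl(phenylcarbamoyl)amino on a saturated chain carbon bound to a saturated ring carbon. For the measured compounds named here, no pair differing in one place has been measured here, so the size of this step is unknown. Compound 2 and compound 3, which also carry a basic nitrogen bearing a substituent at the saturated ring, sit well above compound 1; on that basis compound 4 is expected to give a somewhat higher number, a step of a 3.2-fold higher number from compound 1 to compound 4 (0.51 log units; beyond the scatter). The estimate for compound 4 is 20 nM, within 5 nM to 80 nM.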

Compound 4, half-maximal inhibitory concentration: 8.9 nM
Beside the measured number, compound 4's estimate is 2.2-fold (0.35 log units) above it; measured number inside the range.
By their numbers in this assay, from the lowest: compounds 1 and 4 (each within the scatter of the next); then compound 2; then compound 3.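

In this assay, for the compounds shown here, the first step that changes one place reads a 1.4-fold higher number from compound 1 to compound 4 (0.16 log units; within the scatter), so on a saturated chain carbon bound to a saturated ring carbon, (4-acetamidobenzyl)amino and methyl(phenylcarbamoyl)amino are not told apart. Both groups carry one six-membered aromatic ring of carbon only and one double bond outside aromatic rings. Nothing available here accounts for this result.

Open, going by these compounds, is whether a carboxylic acid in place of the acetamide on the benzyl ring would hold this level. On these data alone, a longer chain between the saturated ring and the amine is equally open.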